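The compounds below may be only part of what the source reports. "The series", "measured", "known", "first", "only" and "open" are said of these compounds alone.

Measured so far in a functional assay on HCT-116 cells (Homo sapiens) for inhibition, read by MTT assay, with a stated time of 48 h; a higher number here means a weaker inhibitor, a lower number a stronger inhibitor:
- compound 1 `COCC(=O)N(Cc1ccc(OC)c(O)c1)c1cc(OC)c(OC)c(OC)c1`, 230 nM
- compound 2 `COC(=O)c1cc(CNc2cc(OC)c(OC)c(OC)c2)ccc1OC`, 38100 nM
- compound 3 `C/C=C/C(=O)N(Cc1ccc(OC)c(Br)c1)c1cc(OC)c(OC)c(OC)c1`, 2800 nM

Compound 1 has the lowest number of the three; compound 3 stands at a higher number beyond the scatter, and compound 2 far higher still. For the measured compounds named here, no single-point step between measured compounds is available, so the size of the change to be tested is not anchored.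

Compound 4 `COc1ccc(CN(C(=O)/C=C/CBr)c2cc(OC)c(OC)c(OC)c2)cc1O` differs from compound 1 by 3-bromoprop-1-en-1-yl in place of methoxymethyl on a carbonyl carbon. The one measured amide with an unsaturated acyl group, compound 3, gives a higher number than compound 1, though it also differs at the ring, so the comparison is loose. In this assay a moderately higher number is expected for compound 4, a step of a 3.5-fold higher number from compound 1 to compound 4 (0.54 log units; beyond the scatter). Compound 4 is estimated at 800 nM, with a range of 150 nM to 4000 nM.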

Compound 4, half-maximal inhibitory concentration: 59 nM
The estimate for compound 4 lay 14-fold (1.13 log units) above the measured number, outside the stated range (below it).
By their numbers in this assay, from the lowest: compound 4; then compound 1; then compound 3; then compound 2.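

On the carbonyl carbon whose other neighbour is the amide-type nitrogen, 3-bromoprop-1-en-1-yl in place of methoxymethyl gives a 3.9-fold lower number from compound 1 to compound 4 (0.59 log units; beyond the scatter) in this assay. For the compounds shown here, this is the first single-place step, and it shows that this position can change with a modest effect on the number and that methoxymethyl is not required there. No measured evidence accounts for the step. On these data alone, whether the bromine or the double bond carries the change stays open. Prop-1-en-1-yl or saturated 3-bromopropyl on the core of compound 1 would separate the two.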